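Phenylsulfanyl replacing furfurylamino on the shared core

The compounds below may be only part of what the source reports. "The series", "measured", "known", "first", "only" and "open" are said of these compounds alone.

Three compounds have numbers in an assay on isolated protein for binding affinity to Equilibrative nucleoside transporter 1 (Homo sapiens); on this read-out lower numbers stand for stronger inhibition and higher numbers for weaker inhibition. Compound 1 `O=[N+]([O-])c1ccc2c(c1)CCN(c1ncnc3c1ncn3[C@@H]1O[C@H](CO)[C@@H](O)[C@H]1O)C2` gives 182 nM in this assay. Compound 2 `OC[C@H]1O[C@@H](n2cnc3c(NCc4ccco4)ncnc32)[C@H](O)[C@@H]1O` gives 36300 nM in this assay. Compound 3 `CSc1ncnc2c1ncn2C1CCCCO1` gives 275000 nM in this assay. Compound 2 therefore stands second highest of the three: above compound 1 by a gap beyond the scatter, and below compound 3 by a gap that is also beyond the scatter. No pair among these three differs in only one place, so no single-step comparison is available.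

The next compound, compound 4 `OC[C@H]1O[C@@H](n2cnc3c(Sc4ccccc4)ncnc32)[C@H](O)[C@@H]1O`, is drawn from compound 2 by one change: phenylsulfanyl in place of ((furan-2-yl)methyl)amino on an aromatic carbon. Compound 3 also carries a sulfur-linked group at the same place on the core but lacks the rest of compound 2's structure, so its weak result in this assay says little about the present step on its own. Compound 1, with a different ring-bearing group at this place, gives 182 nM, which shows the core can reach far stronger inhibition than compound 2.

The step from compound 2 to compound 4 is expected to lower the number well beyond the scatter, a 61-fold lower number from compound 2 to compound 4 (1.78 log units; beyond the scatter). Compound 4 is estimated at 600 nM in this assay, within a range from 100 nM to 5000 nM.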

Compound 4, half-maximal inhibitory concentration: 91200 nM
Compound 4: the middle estimate sits 150-fold (2.18 log units) below what was measured; measured number outside the range, above it.
By their numbers in this assay, from the lowest: compound 1; then compound 2; then compound 4; then compound 3.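

In this assay, phenylsulfanyl in place of ((furan-2-yl)methyl)amino on an aromatic carbon gives a 2.5-fold higher number from compound 2 to compound 4 (0.40 log units; beyond the scatter), so this change weakens inhibition modestly rather than moving the shared core towards stronger inhibition. Both groups hold 7 heavy atoms, so the position tolerates a swap of equal heavy-atom count with only this modest shift, even as it goes from 1 hydrogen-bond donor to 0 hydrogen-bond donors. The link and the ring change together in this single step, and no supporting measurement accounts for the higher number.

Benzylamino, which would keep the amino link while carrying the carbon-only ring, and ((furan-2-yl)methyl)sulfanyl, which would keep the furan ring on a sulfur link, are the two groups that could separate the contribution of the link from that of the ring at this place. Also open, from the compounds shown here alone, is how a plain amine or a longer alkyl chain at this place on the shared core would read in this assay.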